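Cytotoxicity in Mouse Macrophages: From Compound 3 to Compound 4

The source may hold more compounds than are shown below. What is called first, only, known or untested is meant among the compounds shown, and "the series" means these compounds.

Three hydrazone analogues have been tested in an ADME assay on J774 cells (Mus musculus, strain BALB/c) for cytotoxicity, read by resazurin assay, with a stated time of 72 h; a higher number here means that more compound is tolerated, a lower number that less compound is tolerated. Compound 1 `COc1ccc(C(=O)N/N=C(C)/C=N/Nc2ccc([N+](=O)[O-])cc2)cc1` gives > 100000 nM, which is a limit of the assay rather than a number. Compound 2 `CC(/C=N/Nc1ccc([N+](=O)[O-])cc1)=N\NC(=O)c1ccc([N+](=O)[O-])cc1` likewise gives > 100000 nM, again a limit. Compound 3 `COc1cc(C(=O)N/N=C(C)/C=N/Nc2ccc([N+](=O)[O-])cc2)ccc1O` gives > 100000 nM, also a limit. Because all three results sit at the limit of > 100000 nM in this assay, at which 3 of the 3 values shown sit, compound 3 cannot be placed above or below its neighbours. The three steps between them, a step that the two limits leave unreadable from compound 1 to compound 2, a step that the two limits leave unreadable from compound 1 to compound 3 and a step that the two limits leave unreadable from compound 2 to compound 3, are therefore unreadable in size.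

Compound 4 `CC(/C=N/Nc1ccc([N+](=O)[O-])cc1)=N\NC(=O)c1ccccc1C` is yet to be measured in this assay. It differs from compound 3 in this way: 2-methylphenyl in place of 4-hydroxy-3-methoxyphenyl on a carbonyl carbon. Within the data shown here, none of the measured steps gives a readable size, so no direction beyond the scatter can be expected from them. Compound 4 is estimated to give 100000 nM, with a range from 50000 nM to 300000 nM, so that the expected step of a number no higher from compound 3 to compound 4 (the limit leaves the size open) is essentially none, and a further limit is the likeliest outcome.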

Compound 4, half-maximal cytotoxic concentration: > 100000 nM
Compound 4 was reported as a limit; the forecaster's own chance of this, stated with the estimate: 80%; the middle value sits exactly at the limit.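

In this assay compound 4 gives > 100000 nM as a limit of the assay, not a number. Its steps from compound 1, compound 2 and compound 3 cannot be read, because all four results share one limit: the limit of > 100000 nM in this assay, at which 4 of the 4 values shown sit. The compounds shown leave open whether any group swapped on the carbonyl carbon changes cytotoxicity at all.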